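A few compounds are considered here, and "the series" means these few. Any claim that something is new, unique, unknown or untested is made for them only; others in the source may bear on it.

Measured compounds:
compound 1, `Oc1cc(C(F)(F)F)ccc1-c1nc(-c2ccccc2O)n(-c2ccc(Br)cc2)n1`, gives 100% in a functional assay on PC-12 cells (Rattus norvegicus) for cytotoxicity, read by MTT assay, with stated times of 2 h and 24 h, tested at 10 uM; a higher number here means a stronger effect of the compound at the concentration tested, a lower number a weaker effect
compound 2, `Oc1cc(C(F)(F)F)ccc1-c1nc(-c2ccccc2O)n(-c2ccccc2C(F)(F)F)n1`, gives 92.2% in this assay
compound 3, `COc1cccc(-n2nc(-c3ccc(C(F)(F)F)cc3O)nc2-c2ccccc2O)c1`, gives 106% in this assay

Compound 3 holds the highest of the three numbers in this assay. Its nearest neighbour is compound 1, and the step of a number 6 percentage points higher from compound 1 to compound 3 (within the scatter) lies within the scatter, so the two cannot be told apart. The step of a number 13.8 percentage points higher from compound 2 to compound 3 (beyond the scatter) does go beyond the scatter, but only modestly. The whole set sits close to full effect at the concentration tested.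

The next compound, compound 4, is `Oc1cc(C(F)(F)F)ccc1-c1nc(-c2ccccc2O)n(-c2cc(F)cc(F)c2)n1`. It differs from compound 3 as follows: 3,5-difluorophenyl in place of 3-methoxyphenyl on an aromatic nitrogen

All three measured steps concern the same position, the group on the aromatic nitrogen. Two of them, a number 7.8 percentage points lower from compound 1 to compound 2 (within the scatter) and a number 6 percentage points higher from compound 1 to compound 3 (within the scatter), stay within the scatter, and the third, a number 13.8 percentage points higher from compound 2 to compound 3 (beyond the scatter), is modest. Nothing here suggests that exchanging one aryl group for another at this position shifts the read-out by much, so no step beyond the scatter is expected, with at most a slight lowering.

The expected value for compound 4 in this assay is therefore 98%, within a range of 85% to 110%. This estimate corresponds to an expected step of a number 8 percentage points lower from compound 3 to compound 4 (within the scatter).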

Compound 4, a percentage reported as activity, at one concentration (the size of the read-out at that concentration, not a potency): 106%
Beside the measured number, compound 4's estimate is 8 percentage points below it, within the range that was stated.
By their numbers in this assay, from the lowest: compounds 2, 1, 3 and 4 (each within the scatter of the next, the first and the last beyond it).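

In this assay, 3,5-difluorophenyl on the aromatic nitrogen cannot be told apart from 3-methoxyphenyl, with no change at the digits printed from compound 3 to compound 4 (within the scatter) as the step, so among these two compounds the hydrogen-bond acceptor counted for 3-methoxyphenyl and absent from 3,5-difluorophenyl is not needed to hold the read-out. The new group also stays level with 4-bromophenyl, with a number 6 percentage points higher from compound 1 to compound 4 (within the scatter) as the step, whereas a number 13.8 percentage points higher from compound 2 to compound 4 (beyond the scatter) is a modest step of the same size as a number 13.8 percentage points higher from compound 2 to compound 3 (beyond the scatter). This leaves compound 2 with 2-(trifluoromethyl)phenyl set apart from compound 3 and compound 4 but not from compound 1. No measurement bearing on the reason for these steps is available.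

Going by these compounds, all four compounds carry a substituted phenyl at this position, so it stays open whether a carboxylic acid, an amine or a longer alkyl chain in place of that phenyl would move the number at all. With a single concentration and every value close to full effect, the series also leaves open how far the compounds differ in potency, and whether replacing a hydroxyl of the shared core with methoxy would alter the read-out.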